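The source may hold more compounds than are shown below. What is called first, only, known or untested is meant among the compounds shown, and "the series" means these compounds.

Of the compounds shown here, two have been tested so far in a functional assay on U-937 cells (Homo sapiens) for antiproliferative activity, read by MTT assay; on this read-out higher numbers stand for weaker inhibition and lower numbers for stronger inhibition. Compound 1 `COc1ccc2nc(N(Cc3cc(-c4ccccc4F)no3)c3nc4ccc(F)cc4s3)sc2c1` gives 29500 nM. Compound 2 `FC(F)(F)Sc1ccc(-c2cc(CN(c3ncccn3)c3nc4ccccc4s3)on2)cc1` gives 19400 nM. Compound 2 stands at the lower of the two numbers, but its gap to compound 1 lies within the usual scatter of repeated measurements, so the two cannot be told apart on these data. Among the compounds with values here, no step between two measured compounds that differ in a single place has been recorded here, so there is nothing yet that shows how a change at one position moves the numbers.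

Compound 3 `FC(F)(F)Oc1ccc(-c2cc(CN(c3ncccn3)c3nc4ccccc4s3)on2)cc1` has not been measured. Compared with compound 2 it carries trifluoromethoxy in place of (trifluoromethyl)sulfanyl on an aromatic carbon, that is, trifluoromethoxy in place of (trifluoromethyl)sulfanyl on an aromatic carbon. Both groups bring the same count of heavy atoms and the same count of hydrogen-bond acceptors, and nothing measured here speaks for a large shift in either direction. The step expected from compound 2 to compound 3 is therefore a 1.1-fold higher number from compound 2 to compound 3 (0.05 log units; within the scatter), a change not beyond the scatter. For compound 3 in this assay the estimate is 22000 nM, with a range from 9000 nM to 55000 nM.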

Compound 3, half-maximal inhibitory concentration: 13500 nM
Beside the measured number, compound 3's estimate is 1.6-fold (0.21 log units) above it, within the range that was stated.
By their numbers in this assay, from the lowest: compounds 3, 2 and 1 (each within the scatter of the next, the first and the last beyond it).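

In this assay the change from 4-((trifluoromethyl)sulfanyl)phenyl to 4-(trifluoromethoxy)phenyl gives a 1.4-fold lower number from compound 2 to compound 3 (0.16 log units; within the scatter) and so compound 2 and compound 3 cannot be told apart. Within the data shown here, this is the first pair here that differs in one place alone, and it shows that at this aromatic carbon, para to a large group, trading one sulfur for one oxygen, with the heavy-atom and hydrogen-bond acceptor counts unchanged, leaves the number within the usual scatter of repeated measurements. No measurement on hand says what lies behind this result.

The compounds shown carry only these two closely related groups at this position, so the pair says nothing about how a quite different group, such as an amine, a carboxylic acid or a simple methyl, would read there. Also open, going by these compounds, is whether the same exchange would read alike on the core of compound 1, and whether any change at this position can move the number beyond the scatter at all.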